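Removing the long chain from compound 1

This account rests on a few compounds, and the source may have more. Where it says the series, first, only, none or still open, it means among the compounds named here.

Measured values in an ADME assay on microsomes from liver (Mus musculus) for metabolic stability, using NADPH, with a stated time of 10 min (a higher number here means that more of the compound is left, a lower number that less of the compound is left), are these
compound 1 `NCCCCN(C[C@@H]1Cc2ncccc2CN1)[C@H]1CCCc2cccnc21` gives 75%
compound 2 `NCCCCN(C[C@@H]1Cc2cccnc2CN1)[C@H]1CCCc2cccnc21` gives 25%

Going by the values given here, compound 1 stands highest of the two numbers so far. Compound 2 at 25% lies lower, and that gap is beyond the usual scatter. Both compounds carry the same chain and differ in the core, so the gap says nothing about the chain itself.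

The next compound is compound 3 `CN(C[C@@H]1Cc2ncccc2CN1)[C@H]1CCCc2cccnc21`, which keeps the core of compound 1 but not its long chain. The change is hydrogen in place of 3-aminopropyl on a saturated chain carbon bound to an amine nitrogen. Cut one bond further out, the same difference reads 4-aminobutyl to methyl. Among the compounds with values here, no measured pair shows a change of this kind, so any forecast stays loose. Compound 1 at 75% has more room to fall than to rise, so a fall is expected rather than a rise. The expected step in this assay is a modest one, a number 15 percentage points lower from compound 1 to compound 3 (beyond the scatter), only a little beyond the scatter. For compound 3 the estimated value is 60%, within an expected range of 35% to 85%.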

Compound 3, percent of the compound remaining: 0%
For compound 3 the middle estimate is 60 percentage points above the measured one; measured number below the stated range.
By their numbers in this assay, from the lowest: compound 3; then compound 2; then compound 1.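

The earlier pair differed only in the core, while this pair shows that the chain position itself counts in this assay: hydrogen in place of 3-aminopropyl, on a saturated chain carbon bound to an amine nitrogen, gives a number 75 percentage points lower from compound 1 to compound 3 (beyond the scatter) on an unchanged core. The long chain is therefore no passive extra in this read-out, since cutting 4-aminobutyl back to methyl takes the core of compound 1 from the top of these three compounds to the bottom. No data are at hand that bear on why the number moves this far.

Only the full chain and its cut-back form are shown on this core, so it stays open whether a shorter 2-aminoethyl chain, or a 4-hydroxybutyl chain with an alcohol in place of the end amine, would keep the higher number, and so whether chain length or the amine matters more. From the compounds shown here alone, it is also open whether the same cut on the core of compound 2 would bring a step of similar size.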